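From allyl to thiophen-3-yl on the shared core

This account rests on a few compounds, and the source may have more. Where it says the series, first, only, none or still open, it means among the compounds named here.

Three measured compounds share one core: compound 1 `CC1=C(N)[C@@]2(OS1(=O)=O)[C@@H](CO[Si](C)(C)C(C)(C)C)O[C@@H](n1cc(C)c(=O)n(C)c1=O)[C@@H]2O[Si](C)(C)C(C)(C)C`, compound 2 `Cc1cn([C@@H]2O[C@H](CO[Si](C)(C)C(C)(C)C)[C@@]3(OS(=O)(=O)C(I)=C3N)[C@H]2O[Si](C)(C)C(C)(C)C)c(=O)n(C)c1=O` and compound 3 `C=CCC1=C(N)[C@@]2(OS1(=O)=O)[C@@H](CO[Si](C)(C)C(C)(C)C)O[C@@H](n1cc(C)c(=O)n(C)c1=O)[C@@H]2O[Si](C)(C)C(C)(C)C`. In a functional assay on CCRF-CEM cells (Homo sapiens) (a lower number here means that less compound is tolerated, a higher number that more compound is tolerated), compound 1 gives 10000 nM, and compound 2 gives 5600 nM. Between these two lies a 1.8-fold lower number from compound 1 to compound 2 (0.25 log units; within the scatter). Compound 3 gives 45000 nM, the highest of the three numbers.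

Compound 4 `Cc1cn([C@@H]2O[C@H](CO[Si](C)(C)C(C)(C)C)[C@@]3(OS(=O)(=O)C(c4ccsc4)=C3N)[C@H]2O[Si](C)(C)C(C)(C)C)c(=O)n(C)c1=O` has not yet been measured. It carries thiophen-3-yl in place of allyl on a double-bonded ring carbon. Going by the values given here, no measured compound holds thiophen-3-yl, so the evidence comes only from the other groups at this ring carbon. Going from methyl to allyl gave a 4.5-fold higher number from compound 1 to compound 3 (0.65 log units; beyond the scatter), and going from iodo to allyl gave an 8.0-fold higher number from compound 2 to compound 3 (0.91 log units; beyond the scatter). Both steps that arrive at allyl raised the number, while the step between methyl and iodo stayed small. Losing allyl is therefore expected to lower the number in this assay by a step of similar size, although the data cannot show how thiophen-3-yl itself behaves. The expected change is a 3.8-fold lower number from compound 3 to compound 4 (0.57 log units; beyond the scatter). Compound 4 is estimated at 12000 nM, within an expected range of 3000 nM to 45000 nM.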

Compound 4, half-maximal cytotoxic concentration: 33000 nM
Beside the measured number, compound 4's estimate is 2.8-fold (0.44 log units) below it, and the stated range covers the measured number.
By their numbers in this assay, from the lowest: compounds 2 and 1 (each within the scatter of the next); then compounds 4 and 3 (each within the scatter of the next).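

In this assay there is a 1.4-fold lower number from compound 3 to compound 4 (0.13 log units; within the scatter), so at this double-bonded ring carbon thiophen-3-yl, with its five-membered aromatic ring, cannot be told apart from allyl, which has no ring and a double bond outside any aromatic ring. Going by these compounds alone, the higher numbers are therefore not tied to allyl alone, since there is also a 5.9-fold higher number from compound 2 to compound 4 (0.77 log units; beyond the scatter) and a 3.3-fold higher number from compound 1 to compound 4 (0.52 log units; beyond the scatter), both in the same direction as the earlier steps to allyl, and the four groups at this carbon now fall into two sets, methyl and iodo on one side and allyl and thiophen-3-yl on the other. The data shown offer no measurement that would explain this division into two sets.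

The compounds shown leave open where other groups at this ring carbon would fall, for instance phenyl, a saturated propyl chain, an amine or a carboxylic acid. They also leave open whether the two sets would hold once the core's other substituents differ, as all four compounds carry the same groups everywhere else.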